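The compounds below may be only part of what the source reports. "The series", "measured", "known", "first", "only" and "open" are said of these compounds alone.

Compound 1 `Nc1ccccc1NC(=O)/C=C/c1ccc(CSc2cccc(F)c2)cc1`: 7.95%
Compound 2 `CCc1ccc(SCc2ccc(C(=O)Nc3ccccc3N)cc2)cc1`: 40.7%

In a functional assay on HCT-116 cells (Homo sapiens) for inhibition, read by CCK-8 assay, with a stated time of 72 h, tested at 2 uM (a higher number here means more inhibition of growth at the concentration tested, a lower number less inhibition of growth), compound 1 stands lowest of the two measured compounds, and compound 2 lies above it, beyond the scatter. Compound 3 `CC(C)(C)c1ccc(SCc2ccc(/C=C/C(=O)Nc3ccccc3N)cc2)cc1` carries 4-(tert-butyl)phenyl in place of 3-fluorophenyl on a sulfur. Within the data shown here, no measured step shows what this change does, so any expectation is rough. With compound 1 at 7.95%, there is more room upward than downward. A modest upward move is expected, estimated as a number 12.1 percentage points higher from compound 1 to compound 3 (beyond the scatter). For compound 3, the estimated value is 20%, with an expected range of 3% to 50%.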

Compound 3, percent growth inhibition at one concentration: 6.66%
Beside the measured number, compound 3's estimate is 13.3 percentage points above it, within the range that was stated.
By their numbers in this assay, from the lowest: compounds 3 and 1 (each within the scatter of the next); then compound 2.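

In this assay, among these compounds, 4-(tert-butyl)phenyl in place of 3-fluorophenyl on a sulfur gives a number 1.3 percentage points lower from compound 1 to compound 3 (within the scatter) and so shows, for the first time at this position, a swap that leaves the read-out within the scatter, even though the entering group is the larger by heavy-atom count. No evidence at hand bears on this outcome. On these data alone, what an amine, a carboxylic acid or a longer chain on that sulfur would do remains open, as does whether these two groups would also match on the core of compound 2.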